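The compounds below may be only part of what the source reports. "The series", "measured", "known", "first", "only" and "open" are said of these compounds alone.

Measured in a functional assay on SGC-7901 cells (Homo sapiens) for antiproliferative activity, read by MTT assay, with a stated time of 24 h; a higher number here means a weaker inhibitor, a lower number a stronger inhibitor:

Compound 1 `Cc1cccc(NNC(=O)c2ccc(NS(=O)(=O)c3cnc(O)nc3O)cc2)c1`: > 20000 nM
Compound 2 `CCCCOc1ccc(C(=O)NNC(=O)c2ccccc2NS(=O)(=O)c2cnc(O)nc2O)cc1`: 6890 nM

The entry for compound 1, > 20000 nM, is a limit of the assay and not a number. Within the data shown here, compound 2 gives the only true number so far, 6890 nM, which makes it the single fixed point for anything that follows. Among the measured compounds shown here, no pair of measured compounds differs in just one place, so no measured step is available as a guide to how large a single change might be.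

Compound 3 `O=C(NNC(=O)c1ccccc1NS(=O)(=O)c1cnc(O)nc1O)c1ccccc1F` differs from compound 2 in one place: 2-fluorophenyl in place of 4-butoxyphenyl on a carbonyl carbon. In words, 2-fluorophenyl stands in place of 4-butoxyphenyl on a carbonyl carbon. In this assay, a modest move toward a weaker inhibitor is expected, of about the size of the usual scatter. This expectation starts from compound 2 at 6890 nM. Compound 1 stands at > 20000 nM, a limit of the assay, so the weaker side seems the likelier one. The expected change is a 1.7-fold higher number from compound 2 to compound 3 (0.24 log units; within the scatter), and this estimate is loose. For compound 3 the estimated value is 12000 nM, with an expected range from 4000 nM to 20000 nM.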

Compound 3, half-maximal inhibitory concentration: > 20000 nM
Compound 3 was reported as a limit (the forecaster's own chance of this, stated with the estimate: 30%); at least 1.6-fold (0.22 log units) between middle value and limit.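

In this assay, putting 2-fluorophenyl in place of 4-butoxyphenyl on a carbonyl carbon gives an at least 2.9-fold higher number from compound 2 to compound 3 (0.46 log units; beyond the scatter), so what this position carries clearly matters for the read-out. Compound 3 gives > 20000 nM, which is a limit of the assay and not a number. The step therefore has a lower bound but no known upper size, and the loss may be much larger than it appears, because the read-out offers no number for compound 3 and stops at the same limit seen elsewhere in the set: the limit of > 20000 nM in this assay, at which 2 of the 3 values shown sit.

The change removes the butoxy chain and brings in a fluorine at the same time, so the compounds shown leave open which of the two goes with the weaker result, or whether both do. A plain phenyl on the same carbonyl carbon, or a methoxy or hexyloxy group in place of the butoxy chain, would help separate the two and show how the read-out follows the length of that chain.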